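The source may hold more compounds than are shown below. What is called first, only, known or untested is meant among the compounds shown, and "the series" means these compounds.

Measured compounds:
compound 1, `C#CCCCn1c(Cc2cc(OC)c(OC)c(OC)c2)nc2c(N)nc(F)nc21` — 11000 nM
compound 2, `CCC(CC)Cn1c(Cc2cc(OC)c(OC)c(OC)c2)nc2c(N)ncnc21` — 158000 nM
compound 3, `COc1cc(Cc2nc3c(N)nc(F)nc3n2CCOC(C)C)c(Cl)c(OC)c1OC` — 5370 nM

Of the compounds shown here, three sharing one core have been tested in a functional assay on MCF7 cells (Homo sapiens) for antiproliferative activity; a lower number here means a stronger inhibitor, a higher number a weaker inhibitor. Compound 2 stands at the high end of this small set: its number is the largest of the three, and both gaps, to compound 1 and to compound 3, lie beyond the scatter of the method, so compound 2 is the weakest inhibitor of the three. Compound 1 and compound 3 each carry a fluorine on the core that compound 2 lacks, and each carries a different chain on the aromatic nitrogen, so no single change separates compound 2 from either of them.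

Compound 4, `COc1cc(Cc2nc3c(N)ncnc3n2CCCC(C)C)cc(OC)c1OC`, has not yet been measured. It differs from compound 2 only in the chain on the aromatic nitrogen: isopentyl in place of pentan-3-yl on a saturated chain carbon bound to an aromatic nitrogen. The atoms are the same; only the branch point moves. Read one bond further out, the change is 2-ethylbutyl to 4-methylpentyl.

Going by the values given here, no measured pair isolates this kind of change, so the expected step rests on the position of compound 2 alone. A moderate move toward a lower number, beyond the scatter, is expected for the step of a 3.2-fold lower number from compound 2 to compound 4 (0.50 log units; beyond the scatter). Compound 4 is therefore estimated at 50000 nM, with a likely range from 15000 nM to 160000 nM.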

Compound 4, half-maximal inhibitory concentration: 69200 nM
The estimate for compound 4 lay 1.4-fold (0.14 log units) below the measured number; the measured number falls inside the stated range.
By their numbers in this assay, from the lowest: compound 3; then compound 1; then compound 4; then compound 2.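

In this assay, the step is a 2.3-fold lower number from compound 2 to compound 4 (0.36 log units; beyond the scatter): modest, but beyond the scatter, even though the chain on the aromatic nitrogen keeps the same atoms and only its branch point moves. Going by these compounds alone, this is the first direct sign that the arrangement of a saturated five-carbon chain at this position can shift the number, and not only which atoms it contains, though the shift is seen for this single pair. No supporting measurement here explains why moving the branch gives a lower number.

The compounds shown leave open whether an unbranched hexyl chain would continue this move toward a lower number, or whether an amine or a carboxylic acid at the end of the chain would change the picture. They also leave open whether the same move of the branch point would give a step of similar size on a core carrying fluorine, as in compound 1 and compound 3, since neither of those has a partner that differs from it in one place.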